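Urea analogue swaps dichlorophenyl for trifluoromethylphenyl

The source may hold more compounds than are shown below. What is called first, only, known or untested is meant among the compounds shown, and "the series" means these compounds.

For the measured compounds named here, compound 2 `COc1cc(-c2nn(-c3cccc(NC(=O)Nc4ccc(Cl)c(Cl)c4)c3)cc2-c2ccncc2)ccc1Cl` gives 1100 nM in a functional assay on MOLT-4 cells (Homo sapiens) for inhibition, read by sulforhodamine B assay, with a stated time of 48 h (on this read-out lower numbers stand for stronger inhibition of growth and higher numbers for weaker inhibition of growth), the lowest of the two numbers so far, though compound 1 `COc1cc(-c2nn(-c3cccc(NC(=O)c4cccc(C(F)(F)F)c4)c3)cc2-c2ccncc2)ccc1Cl` with 2010 nM sits within the scatter of it. Compound 3 `COc1cc(-c2nn(-c3cccc(NC(=O)Nc4cccc(C(F)(F)F)c4)c3)cc2-c2ccncc2)ccc1Cl` differs from compound 2 by 3-(trifluoromethyl)phenyl in place of 3,4-dichlorophenyl on an amide-type nitrogen. Going by the values given here, the only measured step, a 1.8-fold lower number from compound 1 to compound 2 (0.26 log units; within the scatter), changed both the linker and the aryl group at once and stayed within the scatter, so no step beyond the scatter is expected here either. Compound 3 is therefore expected near compound 2, at 1500 nM with a range of 600 nM to 3800 nM, a step of a 1.4-fold higher number from compound 2 to compound 3 (0.13 log units; within the scatter).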

Compound 3, concentration for 50% growth inhibition: 936 nM
Estimate against measurement, compound 3: 1.6-fold (0.20 log units) above; the measured number falls inside the stated range.
By their numbers in this assay, from the lowest: compounds 3, 2 and 1 (each within the scatter of the next, the first and the last beyond it).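

On the amide-type nitrogen, the exchange of aryl groups gives a 1.2-fold lower number from compound 2 to compound 3 (0.07 log units; within the scatter) in this assay and so does not separate 3-(trifluoromethyl)phenyl from 3,4-dichlorophenyl. For the compounds shown here, with 3-(trifluoromethyl)phenyl held in both compounds, (3-(trifluoromethyl)phenyl)amino in place of 3-(trifluoromethyl)phenyl on a carbonyl carbon gives a 2.1-fold lower number from compound 1 to compound 3 (0.33 log units; beyond the scatter) and is the only step here beyond the scatter, though a modest one. No evidence is available to explain either step. Still open, going by these compounds, is how the number would respond to a cyclohexyl group on that nitrogen, or to an amine or a carboxylic acid on its aryl ring.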